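The source may hold more compounds than are shown below. What is called first, only, known or untested is meant among the compounds shown, and "the series" means these compounds.

In an ADME assay on KB cells (Homo sapiens) for cytotoxicity, read by MTT assay, with a stated time of 72 h (a higher number here means a weaker inhibitor, a lower number a stronger inhibitor), three compounds built on a shared core have been tested, and none of them returns a number. Compound 1 (`COc1ccc(C2=C(c3cc(OC)c(OC)c(OC)c3)C(=O)CC2C)cc1C(=O)O`) reads > 100 ug/mL as a limit of the assay. Compound 2 (`COc1ccc(C2=C(c3cc(OC)c(OC)c(OC)c3)C(=O)CC2O[SiH2]C(C)(C)C)cc1`) reads > 100 ug/mL as a limit too. Compound 3 (`C=CCOc1cc(C2=C(c3cc(OC)c(OC)c(OC)c3)C(=O)C(O)C2)ccc1OC`) reads > 100 ug/mL as a limit as well, and so it has no measured value of its own. Compound 3 therefore stands at the limit of > 100 ug/mL in this assay, at which 3 of the 3 values shown sit, and gives only a floor from which to judge what follows.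

Compound 4 (`COc1ccc(C2=C(c3cc(OC)c(OC)c(OC)c3)C(=O)C(O)C2)cc1F`) has not yet been measured. The change is fluoro in place of allyloxy on an aromatic carbon ( fluoro in place of allyloxy on an aromatic carbon, ortho to a methoxy group ) and everything else stays the same. Among the compounds with values here, no measured step between these compounds shows what such a change does in this assay, so the size of the move is poorly bounded. Since compound 3 reads > 100 ug/mL as a limit, any real change can be expected only toward stronger inhibition, and a second reading at the limit remains quite possible. The expected step, an at least 6.6-fold lower number from compound 3 to compound 4 (0.82 log units; beyond the scatter) in this estimate, is therefore a wide and uncertain one. For compound 4 the estimated value is 15 ug/mL with 1 ug/mL to 100 ug/mL as its expected range.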

Compound 4, half-maximal inhibitory concentration: 4.5 ug/mL
For compound 4 the middle estimate is 3.3-fold (0.52 log units) above the measured one, within the range that was stated.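

The result shows that this aromatic carbon, ortho to a methoxy group, is not indifferent in this assay: with all else the same, fluoro in place of allyloxy gives an at least 22-fold lower number from compound 3 to compound 4 (1.34 log units; beyond the scatter). Compound 3 reads only as a limit, so this size is a floor and not a measured gap, and the true distance between the two compounds may be larger: the limit of > 100 ug/mL in this assay, at which 3 of the 4 values shown sit. The earlier compounds shown here could not show this, as none of them gave a number and no two of them differ in one place, whereas this single change is enough to bring the series into the measurable range.

The compounds shown do not separate what fluoro adds from what the removal of allyloxy takes away, and a plain hydrogen, a chloro, a hydroxyl or an amine on the same carbon would tell these two readings apart. As far as these compounds go, it also stays open how far the result depends on the hydroxyl elsewhere on the shared core, and whether a shorter ether such as methoxy at this carbon would stay at the limit or give a number.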